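Swapping the Five-Membered Ring: What to Expect of Compound 4

The compounds below may be only part of what the source reports. "The series", "measured", "known", "first", "only" and "open" are said of these compounds alone.

Compound 1 `CCSc1nnc(Cc2ccc(Cl)cc2Oc2ccccc2Cl)[nH]1` gives 134% in a functional assay on the whole organism (strain NMRI) with Mus musculus as the target, with a stated time of 60 min, at a dose of 5 mg/kg by the intraperitoneal route; a lower number here means a weaker effect, a higher number a stronger effect of the compound at the dose given.
Compound 2 `CCSc1nnc(Cc2ccc(Cl)cc2Oc2ccccc2F)[nH]1` gives 126% in this assay.
Compound 3 `CCCSc1nnc(Cc2ccc(Cl)cc2Oc2ccccc2F)[nH]1` gives 119% in this assay.

Among these three numbers, compound 2 stands second highest. Its nearest neighbour is compound 3, with a number 7 percentage points lower from compound 2 to compound 3 (within the scatter); its furthest is compound 1, with a number 8 percentage points lower from compound 1 to compound 2 (within the scatter). Both steps lie within the scatter, so the three measured compounds cannot be told apart in this assay.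

Compound 4 `Nc1nnc(Cc2ccc(Cl)cc2Oc2ccccc2F)o1` differs from compound 2 in one place: a group of 6 heavy atoms (2 carbon, 3 nitrogen, 1 oxygen; one five-membered aromatic ring with 3 hetero atoms) in place of a group of 8 heavy atoms (4 carbon, 3 nitrogen, 1 sulfur; one five-membered aromatic ring with 3 hetero atoms), on a saturated chain carbon bound to an aromatic carbon. Neither measured step bears on this change. The step from compound 1 to compound 2 puts fluoro in place of chloro on an aromatic carbon, and the step from compound 2 to compound 3 puts methyl in place of hydrogen on a saturated chain carbon; both leave the five-membered ring untouched. Going by the values given here, the exchange of one five-membered aromatic ring with three hetero atoms for another has no measured example here, so the expectation rests only on the narrow spread of the three values. Compound 4 is expected to give about 115%, within 85% to 140%. This is an expected step of a number 11 percentage points lower from compound 2 to compound 4 (beyond the scatter), with no clear direction beyond the scatter.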

Compound 4, a percentage reported as activity, at one dose (the size of the read-out at that dose, not a potency): 112%
Compound 4: middle estimate off by 3 percentage points, on the high side, and the stated range covers the measured number.
By their numbers in this assay, from the lowest: compounds 4, 3, 2 and 1 (each within the scatter of the next, the first and the last beyond it).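

Putting 5-amino-1,3,4-oxadiazol-2-yl in place of the larger sulfur-bearing ring group, on a saturated chain carbon bound to an aromatic carbon, gives a number 14 percentage points lower from compound 2 to compound 4 (beyond the scatter) in this assay. Going by these compounds alone, the two earlier steps left the five-membered ring untouched and stayed within the scatter, so this is the first sign that the read-out responds to a change at this place, and the response is modest even though the whole group is exchanged. No measurement here explains this step.

This single exchange alters the ring and the group it carries together, so the compounds shown cannot separate the share of each in the step. Also open, from the compounds shown here alone, is what a carboxylic acid in place of the amino group of compound 4 would give, or a butyl chain on the sulfur of compound 3.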